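Side-chain hydroxyl in place of ethyl, compound 3

The source may hold more compounds than are shown below. What is called first, only, known or untested is meant among the compounds shown, and "the series" means these compounds.

Among the measured compounds shown here, compound 1 `CCC[C@H](NC(=O)/C(C#N)=C/c1ccc(Cl)c([N+](=O)[O-])c1)c1ccccc1` gives 1580 nM in a functional assay on MM1 cells (Homo sapiens) for antiproliferative activity, read by MTT assay, with a stated time of 72 h (on this read-out higher numbers stand for weaker inhibition and lower numbers for stronger inhibition), the lower of the two numbers so far. For the measured compounds named here, compound 2 `CCC[C@H](NC(=O)/C(C#N)=C/c1ccc(O)c([N+](=O)[O-])c1)c1ccccc1` gives 8200 nM in this assay; the step of a 5.2-fold higher number from compound 1 to compound 2 (0.72 log units; beyond the scatter) is the only measured change. Compound 3 `N#C/C(=C\c1ccc(Cl)c([N+](=O)[O-])c1)C(=O)N[C@@H](CO)c1ccccc1` differs from compound 1 by hydroxy in place of ethyl on a saturated chain carbon, two bonds along the chain from an amide-type nitrogen and an aromatic carbon. The measured step concerns a hydroxy on an aromatic carbon, not the chain, so it bears only loosely on this change. A modest weakening is expected, a 2.2-fold higher number from compound 1 to compound 3 (0.35 log units; beyond the scatter), with wide uncertainty. Compound 3 is estimated at 3500 nM, range 900 nM to 14000 nM.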

Compound 3, half-maximal inhibitory concentration: > 10000 nM
Compound 3 ended at the assay's limit (the forecaster's own chance of this, stated with the estimate: 5%); middle value at least 2.8-fold (0.45 log units) away from the limit.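

Hydroxy in place of ethyl on the saturated chain carbon gives an at least 6.3-fold higher number from compound 1 to compound 3 (0.80 log units; beyond the scatter) in this assay, so this chain position, which the earlier aromatic step did not touch, also responds to change. No compound shown here keeps any measurable potency in this assay with this change, as far as compound 3 shows. Compound 3 sits at a limit of the assay, so the step has no upper end: the limit of > 10000 nM in this assay, at which 1 of the 3 values shown sits.

The compounds shown do not separate the removal of ethyl from the arrival of hydroxy. On these data alone, how a methoxy, an amine or a longer chain ending in hydroxy would read at this carbon stays open.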